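Adding a second chloro to the aryl ring of compound 3

The compounds below may be only part of what the source reports. "The series", "measured", "known", "first", "only" and "open" are said of these compounds alone.

Three compounds were measured in a functional assay on M14 cells (Homo sapiens) for inhibition, read by sulforhodamine B assay, with a stated time of 48 h; on this read-out lower numbers stand for stronger inhibition of growth and higher numbers for weaker inhibition of growth:

Compound 1, `N#C/C(=C\N1CCN(C(=O)c2ccco2)C1=S)C(N)=O`: 16500 nM
Compound 2, `N#C/C(=C\N1CCN(C(=O)c2ccco2)C1=S)C(=O)c1ccccc1`: 14900 nM
Compound 3, `O=CN1CCN(c2ccc(Cl)cc2)C1=S`: 14600 nM

The three numbers sit close together. Among the compounds with values here, the only step between compounds differing in one place is a 1.1-fold lower number from compound 1 to compound 2 (0.04 log units; within the scatter), which involved a phenyl in place of amino on a carbonyl carbon. Compound 3 carries a different substitution pattern on the shared core, and its number lies within the scatter of both compound 1 and compound 2, so nothing separates it from them.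

Compound 4, `O=CN1CCN(c2ccc(Cl)c(Cl)c2)C1=S`, differs from compound 3 by chloro in place of hydrogen on an aromatic carbon. Within the data shown here, no measured step concerns a change of this kind, since the single step from compound 1 to compound 2 touched a different part of the molecule and stayed within the scatter. Among the measured compounds shown here, with no step pointing either way, the expectation for compound 4 is a number close to that of compound 3, with a step of a 1.2-fold lower number from compound 3 to compound 4 (0.09 log units; within the scatter) that is not expected to exceed the scatter. Compound 4 is therefore estimated at 12000 nM, within a range from 5000 nM to 30000 nM.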

Compound 4, concentration for 50% growth inhibition: 16800 nM
For compound 4 the middle estimate is 1.4-fold (0.15 log units) below the measured one; measured number inside the range.
By their numbers in this assay, from the lowest: compounds 3, 2, 1 and 4 (each within the scatter of the next).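

In this assay, the second chloro enters on an aromatic carbon of the six-membered ring, ortho to the chloro group already present and meta to a group of 8 heavy atoms (a 1.2-fold higher number from compound 3 to compound 4 (0.06 log units; within the scatter)). This is the first step shown on the aryl ring, since the earlier step concerned a different part of the molecule. On this read-out, chloro in place of hydrogen at this position produces no change beyond the scatter, and nothing measured here bears on this result.

The compounds shown leave open whether an amine, a carboxylic acid or a methoxy group at this same position would carry the number beyond the scatter. They also leave open what the existing chloro group of compound 3 contributes to its growth inhibition.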